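Extending the Alkyl Chain on a Shared Core

The compounds below may be only part of what the source reports. "The series", "measured", "known", "first", "only" and "open" are said of these compounds alone.

Measured so far:
compound 1, `NC(=O)c1cn([C@@H]2O[C@H](CO)[C@@H](O)[C@H]2O)nn1`, gives > 200000 nM in a functional assay on CCRF-CEM cells (Homo sapiens); on this read-out higher numbers stand for weaker inhibition and lower numbers for stronger inhibition.
compound 2, `CCCCCCc1cn([C@@H]2O[C@H](CO)[C@@H](O)[C@H]2O)nn1`, gives > 200000 nM in this assay.

For compound 1 the value given is a limit of the assay and not a number. For compound 2 the value given is likewise a limit and not a number. Among the measured compounds shown here, the only measured step, a step that the two limits leave unreadable from compound 1 to compound 2, cannot be read because both values sit at the limit of > 200000 nM in this assay, at which 2 of the 2 values shown sit, so the change from carbamoyl to hexyl on the shared core tells nothing about size or direction.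

Compound 3, `CCCCCCCCc1cn([C@@H]2O[C@H](CO)[C@@H](O)[C@H]2O)nn1`, is not yet measured. It differs from compound 2 by ethyl in place of hydrogen on a saturated chain carbon, six bonds along the chain from an aromatic carbon. For the measured compounds named here, the only measured step that bears on this change is a step that the two limits leave unreadable from compound 1 to compound 2, and it is unreadable; the two chain lengths already seen have therefore not been separated by the numbers. No step beyond the scatter can be expected in this assay in either direction, and a further limit is the most likely outcome.

Compound 3 is estimated at 200000 nM, within a range from 50000 nM to 800000 nM. This estimate means an expected step of a number no higher from compound 2 to compound 3 (the limit leaves the size open).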

Compound 3, half-maximal inhibitory concentration: 44000 nM
For compound 3 the middle estimate is 4.5-fold (0.66 log units) above the measured one, and the stated range ends above it.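

In this assay, among the compounds shown here, ethyl in place of hydrogen on a saturated chain carbon, six bonds along the chain from an aromatic carbon, gives an at least 4.5-fold lower number from compound 2 to compound 3 (0.65 log units; beyond the scatter), the first readable change, whereas the earlier step cannot be read. This shows that the number responds to a change at this position, something the pair of compound 1 and compound 2 could not reveal. The value of compound 2 is a limit and not a number, so the true size of the step stays open, and compound 3 alone carries a measured number: the limit of > 200000 nM in this assay, at which 2 of the 3 values shown sit.

A single readable step cannot show whether the number keeps falling with a longer chain, levels off or rises again. It also leaves open whether the gain depends on the added carbons themselves, as an amine or a carboxylic acid in place of the ethyl on the same chain carbon could help to show.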